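A few compounds are considered here, and "the series" means these few. Any claim that something is new, unique, unknown or untested is made for them only; others in the source may bear on it.

Compound 1 `CNc1cc(Oc2ccc(NC(=O)Nc3ccc(C)c(C(F)(F)F)c3)cc2)ncn1`, compound 2 `Cc1ccc(NC(=O)Nc2ccc(Oc3cc(N4CCNC[C@@H]4C)ncn3)cc2)cc1C(F)(F)F` and the unmeasured compound 3 `C=CC(=O)Nc1cc(Oc2ccc(NC(=O)Nc3ccc(C)c(C(F)(F)F)c3)cc2)ncn1` share one core and differ only in the group carried on an aromatic carbon of it. In a functional assay on BaF3 cells (Mus musculus) for inhibition, read by CCK-8 assay, with a stated time of 72 h (on this read-out lower numbers stand for stronger inhibition of growth and higher numbers for weaker inhibition of growth), compound 1 gives only a limit of the assay, > 10000 nM. That entry is the limit of > 10000 nM in this assay, at which 1 of the 2 values shown sits. In this assay, within the data shown here, compound 2 gives 8120 nM, the single number the set shows. Among the measured compounds shown here, the one measured step, an at least 1.2-fold lower number from compound 1 to compound 2 (0.09 log units; that floor lies within the scatter), sits at its floor within the scatter. Compound 3 differs from compound 2 by (vinylcarbonyl)amino in place of 2-methylpiperazin-1-yl on an aromatic carbon. For the measured compounds named here, no measured step introduces a (vinylcarbonyl)amino group, and the only step known at this aromatic carbon shows no change beyond the scatter, so the data offer no basis for a directional expectation. The expected step is therefore set close to zero, a 1.6-fold lower number from compound 2 to compound 3 (0.21 log units; within the scatter), with a wide band on either side. Compound 3 is estimated at 5000 nM in this assay, with a range from 800 nM to 20000 nM.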

Compound 3, concentration for 50% growth inhibition: 1940 nM
The estimate for compound 3 lay 2.6-fold (0.41 log units) above the measured number, within the range that was stated.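

Until this result the position had shown no change beyond the scatter, so it was unclear whether the group on this aromatic carbon, next to the ring nitrogen, mattered at all in this assay. Replacing the ring of 2-methylpiperazin-1-yl with the open (vinylcarbonyl)amino group gives a 4.2-fold lower number from compound 2 to compound 3 (0.62 log units; beyond the scatter), and changing methyl to vinylcarbonyl on the nitrogen gives an at least 5.1-fold lower number from compound 1 to compound 3 (0.71 log units; beyond the scatter), which makes compound 3 the most potent of the three compounds shown and shows that this position can respond to the group it carries. The second step can be read only as a floor, because the value of compound 1 is a limit and not a number: the limit of > 10000 nM in this assay, at which 1 of the 3 values shown sits.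

From the compounds shown here alone, what remains open is whether the vinyl part or the carbonyl of the new group accounts for the gain, a question that a saturated propanoyl amide or an acetyl amide on the same nitrogen would address. Going by these compounds, how a morpholine, an unsubstituted piperazine or a longer acyl chain would read at this position also remains open.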